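Following one amide series from compound 1 to compound 4

This account rests on a few compounds, and the source may have more. Where it says the series, first, only, none or still open, it means among the compounds named here.

Compound 1 `CCC1(O)CCN(c2nc(C)c3cc(NC(=O)COc4ccc(OC(F)(F)F)cc4)ccc3n2)CC1` is one of three analogues built on a shared core. In an assay on CHO-K1 cells for displacement of a labelled ligand from melanin-concentrating hormone receptor 1 (Homo sapiens), with a stated time of 2 h (on this read-out lower numbers stand for stronger inhibition and higher numbers for weaker inhibition), compound 1 gives 116 nM, the lower of the two numbers reported. Compound 3 `CCC1(O)CCN(c2nc(C)c3cc(NC(=O)COc4ccc(Cl)cc4)ccc3n2)CC1` gives 208 nM in this assay, and the step of a 1.8-fold higher number from compound 1 to compound 3 (0.25 log units; within the scatter) lies within the scatter. Compound 2 `Cc1nc(N2CCC(O)CC2)nc2ccc(NC(=O)C(C)(C)Oc3ccc(Cl)cc3)cc12` yields only a limit of > 10000 nM in this assay, a case of the limit of > 10000 nM in this assay, at which 1 of the 3 values shown sits. Compound 4 `Cc1nc(N2CCN(C3CCOCC3)CC2)nc2ccc(NC(=O)COc3ccc(OC(F)(F)F)cc3)cc12` carries the change (4-(oxan-4-yl)piperazin-1-yl in place of 4-ethyl-4-hydroxypiperidin-1-yl on an aromatic carbon). Within the data shown here, no measured step touches this part of the molecule; the single measured step, a 1.8-fold higher number from compound 1 to compound 3 (0.25 log units; within the scatter), concerns a different group. With nothing pointing either way, compound 4 is expected to give about 150 nM, within 35 nM to 1500 nM. The expected step is therefore a 1.3-fold higher number from compound 1 to compound 4 (0.11 log units; within the scatter), uncertain in direction.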

Compound 4, half-maximal inhibitory concentration: 7 nM
Beside the measured number, compound 4's estimate is 21-fold (1.33 log units) above it, outside the stated range (below it).
By their numbers in this assay, from the lowest: compound 4; then compounds 1 and 3 (each within the scatter of the next). At a limit, above all of these: compound 2.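

Among these compounds, the group at this position of the shared core proves decisive: in this assay, 4-(oxan-4-yl)piperazin-1-yl in place of 4-ethyl-4-hydroxypiperidin-1-yl gives a 17-fold lower number from compound 1 to compound 4 (1.22 log units; beyond the scatter) while the only earlier step, elsewhere in the molecule, stayed within the scatter. The change also swaps one ring for two and removes the hydrogen-bond donor, and this single step cannot separate these differences. Nothing measured here accounts for the gain.

Left open is whether the oxane ring is needed, or whether a plain piperazine or a 4-methylpiperazin-1-yl group would serve as well. Also open, going by these compounds, is whether the gain carries over to the chloro amide of compound 3.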